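Exchanging one aromatic group on compound 1

The source may report more compounds than this note shows. Statements on the series, on what has been measured and on what is new or still open speak of the compounds shown alone.

Compound 1 `O=C(/C(=C\c1ccc([N+](=O)[O-])c(O)c1)SCc1ccc(Br)cc1)c1ccc(Br)cc1` is a growth inhibitor of prostate cancer cells. In a functional assay on DU-145 cells (Homo sapiens) for inhibition, read by trypan blue exclusion, with a stated time of 96 h (on this read-out lower numbers stand for stronger inhibition of growth and higher numbers for weaker inhibition of growth), compound 1 gives 10000 nM. Among the compounds with values here, this is the only plain number in the data, since the other value is a limit. Compound 2 `O=C(/C(=C\c1ccc([N+](=O)[O-])c(O)c1)SCc1ccc(Br)cc1)C1CCNC1` returns only a limit of this assay, > 100000 nM. Within the data shown here, the one measured step, an at least 10-fold higher number from compound 1 to compound 2 (1.00 log units; beyond the scatter), changes the group on the carbonyl carbon and is supported by the limit of > 100000 nM in this assay, at which 1 of the 2 values shown sits.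

Compound 3 `O=C(/C(=C\c1ccc(O)c(C(=O)O)c1)SCc1ccc(Br)cc1)c1ccc(Br)cc1` differs from compound 1 elsewhere: 3-carboxy-4-hydroxyphenyl in place of 3-hydroxy-4-nitrophenyl on a double-bonded chain carbon bound to a double-bonded chain carbon. The measured step from compound 1 to compound 2 concerns a different part of the shared core, so it tells nothing about how this aromatic swap will play out. Among the measured compounds shown here, with no measured step bearing on it, the expectation for compound 3 must stay close to compound 1 with a broad allowance either way. The step from compound 1 to compound 3 is therefore expected to be a 1.5-fold higher number from compound 1 to compound 3 (0.18 log units; within the scatter), within scatter. Compound 3 is estimated at 15000 nM, with a range from 4000 nM to 60000 nM.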

Compound 3, concentration for 50% growth inhibition: 10000 nM
Compound 3: middle estimate off by 1.5-fold (0.18 log units), on the high side, and the stated range covers the measured number.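

The exchange of 3-hydroxy-4-nitrophenyl for 3-carboxy-4-hydroxyphenyl on a double-bonded chain carbon bound to a double-bonded chain carbon gives no change at the digits printed from compound 1 to compound 3 (within the scatter) in this assay, so this position accepts a clearly different set of atoms without any visible effect on the read-out. Within the data shown here, the earlier compounds showed only that a change on the carbonyl carbon could weaken growth inhibition, whereas this pair shows that the nitro group can be lost, and a carboxylic acid brought in, while the number stays the same. The data shown give no reason why the two groups perform alike, and the fact that the two numbers match does not mean the two groups act in the same way.

From the compounds shown here alone, it remains open whether any substituent on this aromatic ring matters at all, since a plain phenyl group, or a ring carrying an amine or a nitrile, would test how far this tolerance extends. Going by these compounds, it is also open whether the same freedom would hold if the 4-bromophenyl group on the carbonyl carbon were replaced at the same time.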